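The compounds below may be only part of what the source reports. "The series", "measured", "known", "first", "only" and "open" are said of these compounds alone.

Values so far in an ADME assay on microsomes from liver (Mus musculus) for metabolic stability, read by LC-MS, with a stated time of 30 min, tested at 1 uM; on this read-out lower numbers stand for a less stable compound and higher numbers for a more stable compound
compound 1 `O=C(NCc1ccc(S(=O)(=O)c2ccccc2)cc1)c1nc2cnccc2[nH]1` gives 7.3%
compound 2 `O=C(NCc1ccc(S(=O)(=O)c2ccccc2)cc1)c1ccc2nccn2c1` gives 18%
compound 3 `O=C(NCc1ccc(S(=O)(=O)c2ccccc2)cc1)c1c[nH]c2ccncc12` gives 45%

Compound 3 stands highest of the three (45%), and both gaps to the other compounds lie beyond the scatter. Compound 4 `O=C(NCc1ccc(S(=O)(=O)c2ccccc2)cc1)c1ccc2nncn2c1` comes from compound 3 through one change (a group of 9 heavy atoms (6 carbon, 3 nitrogen; one five-membered aromatic ring with 3 hetero atoms, one six-membered aromatic ring with 1 hetero atom) in place of a group of 9 heavy atoms (7 carbon, 2 nitrogen; one five-membered aromatic ring with 1 hetero atom, one six-membered aromatic ring with 1 hetero atom), on a carbonyl carbon).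

Three measured steps at this place bear on it: a large one (a number 37.7 percentage points higher from compound 1 to compound 3 (beyond the scatter)) and two modest ones (a number 27 percentage points higher from compound 2 to compound 3 (beyond the scatter)) and (a number 10.7 percentage points higher from compound 1 to compound 2 (beyond the scatter)). Compounds 1 and 2 both carry a five-membered aromatic ring with 2 hetero atoms and both lie lower than compound 3, whose ring has 1 hetero atom. For the measured compounds named here, no measured compound has a ring with 3 hetero atoms, so the expectation is an extrapolation from these three compounds alone. A downward step of modest size is expected in this assay (a number 23 percentage points lower from compound 3 to compound 4 (beyond the scatter)). The estimate for compound 4 is 22% (expected range 7% to 45%).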

Compound 4, percent of the compound remaining: 47%
Compound 4: the middle estimate sits 25 percentage points below what was measured; the measured number lies above the stated range.
By their numbers in this assay, from the lowest: compound 1; then compound 2; then compounds 3 and 4 (each within the scatter of the next).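

In this assay, the count of hetero atoms in the five-membered aromatic ring on the carbonyl carbon does not order these compounds: the group with 3 hetero atoms stands level with the group with 1 hetero atom (a number 2 percentage points higher from compound 3 to compound 4 (within the scatter)) and apart from both groups with 2 hetero atoms (a number 29 percentage points higher from compound 2 to compound 4 (beyond the scatter); a number 39.7 percentage points higher from compound 1 to compound 4 (beyond the scatter)). Compounds 1, 2 and 3 alone allowed a reading in which more hetero atoms in that ring go with a lower number, and compound 4 goes against it; a group with 0 hydrogen-bond donors also matches compound 3, whose group has 1. No evidence on the cause of these differences is at hand.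

On these data alone, whether a methyl or an amine on the group of compound 4 would hold this level remains open. So does whether a methyl on the amide-type nitrogen would change it.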